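Cytotoxicity in a phenol-diene series: ester versus hydrazone

This account rests on a few compounds, and the source may have more. Where it says the series, first, only, none or still open, it means among the compounds named here.

Measured so far in an ADME assay on HEK293 cells (Homo sapiens) for cytotoxicity, with a stated time of 72 h; on this read-out lower numbers stand for an effect already at smaller amounts and higher numbers for an effect only at larger amounts of compound:
- compound 1 `C=C[C@@](C)(/C=C/c1ccc(O)cc1)CC/C=C/C(=O)OCC`: > 36600 nM
- compound 2 `C=C[C@@](C)(/C=C/c1ccc(O)cc1)CC/C=C(C)/C=N/N`: > 36600 nM

Both values are limits of this assay, not numbers. For compound 2 the value > 36600 nM is such a limit. Where compound 2 stands can therefore be given only as the limit of > 36600 nM in this assay, at which 2 of the 2 values shown sit; nothing places it above or below compound 1.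

Among the measured compounds shown here, the one measured step, a step that the two limits leave unreadable from compound 1 to compound 2, cannot be read, since the two limits hide its size.

Compound 3 `C=C[C@@](C)(/C=C/c1ccc(O)cc1)CC/C=C(\C)C(=O)OCC` differs from compound 2 by a group of 5 heavy atoms (3 carbon, 2 oxygen; no ring) in place of a group of 3 heavy atoms (1 carbon, 2 nitrogen; no ring), on a double-bonded chain carbon bound to a double-bonded chain carbon and a saturated chain carbon. This brings back the ethoxycarbonyl of compound 1, now carrying a methyl on the double-bonded chain carbon. Since compound 1, with > 36600 nM, also sits at the limit, no step beyond the scatter is expected here; the most likely outcome is again a limit.

Compound 3 is expected at 50000 nM, within 20000 nM to 150000 nM. The expected step that the limit leaves unreadable from compound 2 to compound 3 is thus none beyond the scatter.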

Compound 3, half-maximal effective concentration: > 36600 nM
Compound 3 ended at the assay's limit; the forecaster's own chance of this, stated with the estimate: 85%; the middle value does not contradict the limit.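

In this assay compound 3 gives > 36600 nM, which is a limit and not a number. With compound 1 and compound 2 also at a limit, no step among these compounds can be read: the limit of > 36600 nM in this assay, at which 3 of the 3 values shown sit.

The compounds shown leave open at what concentration any of them reaches a half-maximal effect, and whether the ethoxycarbonyl exchange alters that concentration at all.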